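A second fluoro on the aromatic ring of compound 2

The source may report more compounds than this note shows. Statements on the series, on what has been measured and on what is new or still open speak of the compounds shown alone.

Measured compounds and their values:
compound 1 `CC(O[C@H]1CC[C@]2(CC1)COC(C)(C)C2)c1nc(-c2ccc(CS(C)(=O)=O)c(F)c2)no1` gives 44 nM
compound 2 `C[C@@H](O[C@H]1CC[C@]2(CC1)COC(C)(C)C2)c1nc(-c2ccc(CS(C)(=O)=O)c(F)c2)no1` gives 27 nM
compound 3 `CC(O[C@H]1CC[C@]2(CC1)COC(C)(C)C2)c1nc(-c2ccc(CS(C)(=O)=O)cc2)no1` gives 426 nM

All three were run in a functional assay on HEK293 cells for agonist activity at Glucose-dependent insulinotropic receptor (Homo sapiens), read by cAMP accumulation, with a stated time of 30 min; on this read-out higher numbers stand for an effect only at larger amounts of compound and lower numbers for an effect already at smaller amounts. Compound 3 and compound 1 differ by fluoro in place of hydrogen on an aromatic carbon, and the step is a 9.7-fold lower number from compound 3 to compound 1 (0.99 log units; beyond the scatter). Compound 1 and compound 2 have the same atoms and bonds; the step of a 1.6-fold lower number from compound 1 to compound 2 (0.21 log units; within the scatter) is within the scatter, and the only difference between them is the fact that one of compounds 1 and 2 is drawn with a defined configuration and the other without, at the place where they differ. The difference between the cores of compound 2 and compound 3 is not broken down here.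

Compound 4 `C[C@@H](O[C@H]1CC[C@]2(CC1)COC(C)(C)C2)c1nc(-c2cc(F)c(CS(C)(=O)=O)cc2F)no1` has not yet been measured. It differs from compound 2 by fluoro in place of hydrogen on an aromatic carbon. Going by the values given here, this is the same kind of change as the one from compound 3 to compound 1, but not the same: in that earlier case the entering fluoro sat ortho to a (methylsulfonyl)methyl group and meta to a large group, whereas in compound 4 it sits ortho to a large group, meta to a (methylsulfonyl)methyl group and para to a fluoro group.

In this assay a step of a 1.8-fold lower number from compound 2 to compound 4 (0.26 log units; within the scatter) is expected, smaller than the measured step of a 9.7-fold lower number from compound 3 to compound 1 (0.99 log units; beyond the scatter), because the surroundings of the new fluoro in compound 4 differ from those in compound 1 and the value of compound 2 27 nM already stands lowest of the three. Compound 4 is therefore estimated at 15 nM, with a plausible range from 5 nM to 45 nM.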

Compound 4, half-maximal effective concentration: 64 nM
Compound 4: middle estimate off by 4.3-fold (0.63 log units), on the low side; the measured number lies above the stated range.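

In this assay, fluoro in place of hydrogen on an aromatic carbon does not carry over as a fixed increment in this series, and a 2.4-fold higher number from compound 2 to compound 4 (0.37 log units; beyond the scatter) runs against the direction of the earlier step: the same change on two cores in this assay, a 9.7-fold lower number (0.99 log units; beyond the scatter) from compound 3 to compound 1 and a 2.4-fold higher number (0.37 log units; beyond the scatter) from compound 2 to compound 4, 23-fold (1.36 log units) apart, beyond the scatter of two such steps

The two steps are not the same substitution, however: in compound 4 the entering fluoro sits ortho to a large group, meta to a (methylsulfonyl)methyl group and para to a fluoro group, on a ring that already carries a fluoro, whereas the fluoro of compound 1 stands at another place on a ring that carried none. The pairs therefore show that the gain from the first fluoro is not repeated by a second one at this other place, but they do not separate the effect of that place from the effect of the fluoro already present, and they give no mechanism for the reversal.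

Open, from the compounds shown here alone, is how a lone fluoro at the place it takes in compound 4 would behave on the ring of compound 3. Also open, going by these compounds, is whether chloro, methyl or a nitrile at that place would follow fluoro, or whether a carboxylic acid in place of the (methylsulfonyl)methyl group would change the picture.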